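The source may hold more compounds than are shown below. What is called first, only, known or untested is meant among the compounds shown, and "the series" means these compounds.

Measured in a functional assay on P388 cells (Mus musculus) for cytotoxicity; on this read-out higher numbers stand for weaker inhibition and lower numbers for stronger inhibition:
- Compound 1 `Cc1cc(-c2c(F)cc3c(=O)c(Cc4cccc(O)c4)cn(C4CC4)c3c2F)cc(C)n1`: 2200 nM
- Compound 2 `COc1ccc(Cc2cn(C3CC3)c3c(F)c(-c4cc(C)nc(C)c4)c(F)cc3c2=O)cc1`: 21000 nM
- Compound 3 `Cc1cc(-c2c(F)cc3c(=O)c(Cc4ccc[nH]4)cn(C4CC4)c3c2F)cc(C)n1`: 930 nM

Compound 3 has the lowest number of the three. Compound 4 `Cc1cc(-c2c(F)cc3c(=O)c(C(=O)O)cn(C4CC4)c3c2F)cc(C)n1` differs from it by carboxy in place of (1H-pyrrol-2-yl)methyl on an aromatic carbon.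

The closest evidence comes from swapping the ring on the chain carbon. There is a 9.5-fold higher number from compound 1 to compound 2 (0.98 log units; beyond the scatter), then a 2.4-fold lower number from compound 1 to compound 3 (0.37 log units; beyond the scatter), and the largest is a 23-fold lower number from compound 2 to compound 3 (1.35 log units; beyond the scatter). None of these removes the chain, so they show how far this place can move the number but give no direction for carboxy.

Since compound 3 already sits lowest at 930 nM, a modest step toward a higher number is expected in this assay. The estimated change is a 3.2-fold higher number from compound 3 to compound 4 (0.51 log units; beyond the scatter). For compound 4 the estimate is 3000 nM, with an expected range of 700 nM to 13000 nM.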

Compound 4, half-maximal inhibitory concentration: 29000 nM
The estimate for compound 4 lay 9.7-fold (0.99 log units) below the measured number, outside the stated range (above it).
By their numbers in this assay, from the lowest: compound 3; then compound 1; then compounds 2 and 4 (each within the scatter of the next).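

In this assay, carboxy at this aromatic carbon gives a 31-fold higher number from compound 3 to compound 4 (1.49 log units; beyond the scatter) and a 13-fold higher number from compound 1 to compound 4 (1.12 log units; beyond the scatter) as large steps, while a 1.4-fold higher number from compound 2 to compound 4 (0.14 log units; within the scatter) stays within the scatter. The chain-borne rings therefore do not all differ from carboxy alike: (1H-pyrrol-2-yl)methyl and 3-hydroxybenzyl stand clearly apart from it, but 4-methoxybenzyl does not. Nothing available explains these steps. The compounds shown leave open whether a carboxamide or an aminomethyl group at this carbon would fall nearer compound 3 or compound 4.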